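What a Methoxy Group Might Do to Compound 2

This account rests on a few compounds, and the source may have more. Where it says the series, first, only, none or still open, it means among the compounds named here.

In a functional assay on SK-MEL-28 cells (Homo sapiens) for inhibition, read by colorimetric assay and MTT assay, with a stated time of 72 h (on this read-out lower numbers stand for stronger inhibition and higher numbers for weaker inhibition), compound 1 (`C=CCCOc1ncc(-c2ccccc2OC)n1C`) gives 21000 nM as its result and compound 2 (`C=CCCCCOc1ncc(-c2ccccc2OC)n1C`) gives 13000 nM as its result. Among the measured compounds shown here, these two values share the low end of the three known numbers, and the chain change linking them is small (a 1.6-fold lower number from compound 1 to compound 2 (0.21 log units; within the scatter)). Compound 3 (`C=CCCCCOc1ncc(-c2ccc(Cl)cc2OC)n1C`) carries a chloro group on the aromatic ring and gives 50000 nM in the same test. That change is the clearer one (a 3.8-fold higher number from compound 2 to compound 3 (0.59 log units; beyond the scatter)) and it moves the number away from compound 2.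

Compound 4 (`C=CCCCCOc1ncc(-c2cccc(OC)c2OC)n1C`) has not been measured. It differs from compound 2 by one change (methoxy in place of hydrogen on an aromatic carbon): methoxy in place of hydrogen on an aromatic carbon, ortho to a methoxy group. The chain step says little about this change. The chloro step (a 3.8-fold higher number from compound 2 to compound 3 (0.59 log units; beyond the scatter)) is the nearest guide, since it also replaces a hydrogen on an aromatic carbon, yet it involves a different group at a different place. For the measured compounds named here, no measured step adds a methoxy group, so the guide is loose. A modest move toward a higher number is expected (a 2.2-fold higher number from compound 2 to compound 4 (0.33 log units; beyond the scatter)) and no larger than the chloro step. Compound 4 is estimated at 28000 nM in this assay with an expected range from 10000 nM to 80000 nM as its limits.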

Compound 4, half-maximal inhibitory concentration: 27000 nM
Compound 4: the middle estimate sits 1.0-fold (0.02 log units) above what was measured; measured number inside the range.
By their numbers in this assay, from the lowest: compounds 2, 1, 4 and 3 (each within the scatter of the next, the first and the last beyond it).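

Putting methoxy in place of hydrogen on the aromatic carbon ortho to a methoxy group gives a 2.1-fold higher number from compound 2 to compound 4 (0.32 log units; beyond the scatter) in this assay and so weakens inhibition by a modest step rather than strengthening it. Among the compounds shown here, until now, the only change on this ring was the chloro group, which gave a 3.8-fold higher number from compound 2 to compound 3 (0.59 log units; beyond the scatter) at a different ring carbon, so two different groups at two different places now both move the number upward from compound 2, and neither addition to the ring lowers it. Nothing measured here explains why the added methoxy group has this effect on the number.

Going by these compounds, whether a smaller group such as fluoro or hydroxyl on the same aromatic carbon would also raise the number remains open, and so does whether any group on this ring could lower it below the value of compound 2. It is equally open how an amine or a carboxylic acid on the chain would behave, since every compound shown keeps a plain hydrocarbon chain ending in a double bond.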